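Reversing the amide at the saturated ring carbon

This account rests on a few compounds, and the source may have more. Where it says the series, first, only, none or still open, it means among the compounds named here.

Going by the values given here, compound 2 `Cc1nn(-c2ncnc3nc[nH]c23)c2c1C(C(=O)NCc1ccccc1)CC(=O)N2` gives 5 nM in a functional assay on HEK293 cells for agonist activity at G-protein coupled receptor 39 (Homo sapiens), read by scintillation proximity assay and inositol phosphate accumulation, with a stated time of 75 min, in the presence of a further agent that is not named here (a lower number here means that less compound is needed, a higher number that more compound is needed for the effect), the higher of the two numbers measured so far, though the nearest neighbour, compound 1 `Cc1nn(-c2ncnc3nc[nH]c23)c2c1C(OCc1ccccc1F)CC(=O)N2`, gives 4 nM in this assay and the gap between them is within the scatter. Compound 3 `Cc1nn(-c2ncnc3nc[nH]c23)c2c1C(NC(=O)c1ccccc1)CC(=O)N2` has not been measured; it carries benzamido in place of benzylcarbamoyl on a saturated ring carbon, so the amide at this saturated ring carbon is turned around. Among the compounds with values here, the only measured step at this position is a 1.3-fold higher number from compound 1 to compound 2 (0.10 log units; within the scatter), where an ether gave way to an amide without a change beyond the scatter. That step suggests this position tolerates a change of the attached group, but no reversed amide has been measured, so the estimate is uncertain. Compound 3 is therefore expected to give about 12 nM in this assay, with a range from 3 nM to 50 nM. The expected step of a 2.4-fold higher number from compound 2 to compound 3 (0.38 log units; beyond the scatter) is a modest loss.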

Compound 3, half-maximal effective concentration: 3 nM
Estimate against measurement, compound 3: 4.0-fold (0.60 log units) above; low and high end bracket the measured number.
By their numbers in this assay, from the lowest: compounds 3, 1 and 2 (each within the scatter of the next).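

Turning the amide around at this saturated ring carbon gives a 1.7-fold lower number from compound 2 to compound 3 (0.22 log units; within the scatter) in this assay, so the direction of the amide does not separate these two compounds. Benzamido also stays close to the ether, with a 1.3-fold lower number from compound 1 to compound 3 (0.12 log units; within the scatter) for that exchange, and all three groups shown on this carbon, (2-fluorobenzyl)oxy, benzylcarbamoyl and benzamido, now lie within the scatter of one another. Nothing available gives an explanation for this result.

Each of these three groups carries a six-membered aromatic ring of carbon only, so the compounds shown say nothing about a group on this carbon without such a ring. From the compounds shown here alone, whether a primary amine, a carboxylic acid or a short alkyl chain would hold the number in this assay stays open, as does the effect of substituents on the benzamido ring.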